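Aryl variation on the shared core: outlook for compound 4

The source may hold more compounds than are shown below. What is called first, only, known or untested is meant among the compounds shown, and "the series" means these compounds.

Three analogues on one shared core have been measured in a functional assay on MDA-MB-468 cells (Homo sapiens) for inhibition, read by sulforhodamine B assay, with a stated time of 48 h, tested at 10 uM; on this read-out lower numbers stand for less inhibition and higher numbers for more inhibition at the one concentration tested (going by the name of the read-out). Compound 1 `Fc1ccc(-c2cn3ccnc3c(-c3ccc4ncn(C5CCCCC5)c4c3)n2)cc1` gives 19.5%. Compound 2 `c1cn2cc(-c3ccsc3)nc(-c3ccc4ncn(C5CCCCC5)c4c3)c2n1` gives 21.8%. Compound 3 `Brc1ccc(-c2cn3ccnc3c(-c3ccc4ncn(C5CCCCC5)c4c3)n2)cc1` gives 33.7%. Compound 2 stands second highest of the three: the step of a number 2.3 percentage points higher from compound 1 to compound 2 (within the scatter) is within the scatter, whereas a number 11.9 percentage points higher from compound 2 to compound 3 (beyond the scatter) and a number 14.2 percentage points higher from compound 1 to compound 3 (beyond the scatter) are both beyond it and modest in size.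

Compound 4 `COc1ccccc1-c1cn2ccnc2c(-c2ccc3ncn(C4CCCCC4)c3c2)n1` is not yet measured. Relative to compound 2 the change is 2-methoxyphenyl in place of thiophen-3-yl on an aromatic carbon. Two measured steps exchange the group at this same position and so bear on it: a number 2.3 percentage points higher from compound 1 to compound 2 (within the scatter) shows that 4-fluorophenyl and thiophen-3-yl give numbers within the scatter of each other, and a number 11.9 percentage points higher from compound 2 to compound 3 (beyond the scatter) shows that 4-bromophenyl gives a modest rise beyond it. Among the compounds with values here, a phenyl bearing one substituent therefore comes out somewhere between no change and a modest rise, and there is no measured example of a 2-methoxyphenyl to narrow this further. For compound 4 a step of a number 4.2 percentage points higher from compound 2 to compound 4 (within the scatter) in this assay is expected, small and possibly within the scatter. The estimate for compound 4 is 26%, with a range from 12% to 40%.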

Compound 4, a percentage reported as inhibition, at one concentration (the size of the read-out at that concentration, not a potency): 14.6%
Beside the measured number, compound 4's estimate is 11.4 percentage points above it; the measured number falls inside the stated range.
By their numbers in this assay, from the lowest: compounds 4, 1 and 2 (each within the scatter of the next); then compound 3.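

Working notes: in this assay, 2-methoxyphenyl at this position cannot be told apart from thiophen-3-yl (a number 7.2 percentage points lower from compound 2 to compound 4 (within the scatter)) or from 4-fluorophenyl (a number 4.9 percentage points lower from compound 1 to compound 4 (within the scatter)), so the larger entering group, 8 heavy atoms against 5 for thiophen-3-yl, brings no rise that can be read. Within the data shown here, the only step here beyond the scatter is the one involving 4-bromophenyl (a number 19.1 percentage points lower from compound 3 to compound 4 (beyond the scatter)), so a substituted phenyl as such does not set the number apart, with compound 1 and compound 4 both going against any such rule and compound 3 alone standing clear of them. No data on the origin of these differences are at hand.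

Still open, from the compounds shown here alone, is whether the higher number of compound 3 goes with bromo itself or with its placing on the phenyl, which a 2-bromophenyl or a 4-methoxyphenyl analogue on the shared core would help to separate. The compounds shown also say nothing about a phenyl carrying an amine or a carboxylic acid at this position, or about any change elsewhere on the shared core.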